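The compounds below may be only part of what the source reports. "The series", "measured", "known", "first", "only" and "open" are said of these compounds alone.

Measured so far:
- compound 1, `COc1ccc(Nc2nc3ccccc3nc2S(=O)(=O)c2ccccc2)cc1`: 11900 nM
- compound 2, `COc1cc(Nc2nc3ccccc3nc2S(=O)(=O)c2ccccc2)cc(OC)c1`: 70 nM

In a functional assay on A549 cells (Homo sapiens) for cytotoxicity, read by MTT assay, with a stated time of 72 h (on this read-out higher numbers stand for weaker inhibition and lower numbers for stronger inhibition), compound 2 stands lowest of the two numbers; its nearest neighbour is compound 1, and the change a 170-fold lower number from compound 1 to compound 2 (2.23 log units; beyond the scatter) separates them. Compound 3, `COc1cc(Nc2nc3ccccc3nc2S(=O)(=O)c2ccccc2)cc(OC)c1OC`, has not been measured. Its difference from compound 2 is methoxy in place of hydrogen on an aromatic carbon, on the aromatic ring attached to the nitrogen. Among the compounds with values here, only one measured step exists, and it concerns a different change to the same ring: shifting methoxy groups between positions rather than adding a third one. That step was large, which shows that this assay responds strongly to the methoxy pattern on that ring. Within the data shown here, no step tells directly what a third methoxy does, so the expectation for compound 3 is a modest movement, most likely a small decrease in this assay, amounting to a 2.0-fold lower number from compound 2 to compound 3 (0.30 log units; within the scatter). Compound 3 is therefore estimated at 35 nM, within a range of 6 nM to 250 nM.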

Compound 3, half-maximal inhibitory concentration: 9660 nM
Compound 3: middle estimate off by 280-fold (2.44 log units), on the low side; the measured number lies above the stated range.
By their numbers in this assay, from the lowest: compound 2; then compounds 3 and 1 (each within the scatter of the next).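

In this assay, methoxy in place of hydrogen on the aromatic carbon ortho to two methoxy groups and para to a large group gives a 140-fold higher number from compound 2 to compound 3 (2.14 log units; beyond the scatter), so this single place can by itself remove the low number of compound 2. The earlier step swapped one methoxy pattern for another, whereas this one shows that adding one methoxy, with the other two left where they are, is enough for a large move. No evidence is at hand on what lies behind this rise.

The compounds shown leave open whether the rise belongs to methoxy or to any group at this place. A fluorine atom, a hydroxyl or a methyl group there, on the 3,5-dimethoxyphenyl of compound 2, would tell these cases apart.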